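Two Calpain-1 Inhibitors and a Tetrahydroquinolinylethyl Analogue

The source may report more compounds than this note shows. Statements on the series, on what has been measured and on what is new or still open speak of the compounds shown alone.

The two measured compounds share a common core and differ only in the group carried on a saturated chain carbon bound to an amide-type nitrogen. Compound 1 `CCC(NC(=O)C(CC(C)C)NC(=O)OCc1ccccc1)C(=O)C(=O)NCCCc1ccccc1` gives 800 nM in an assay on isolated protein for inhibition of Calpain-1 catalytic subunit (Homo sapiens); on this read-out higher numbers stand for weaker inhibition and lower numbers for stronger inhibition. Compound 2 `CCC(NC(=O)C(CC(C)C)NC(=O)OCc1ccccc1)C(=O)C(=O)NCc1nccc2ccccc12` gives 250 nM in this assay. The single measured step, a 3.2-fold lower number from compound 1 to compound 2 (0.51 log units; beyond the scatter), places compound 2 at the lowest of the two numbers shown, with compound 1 as its only neighbour.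

Compound 3 `CCC(NC(=O)C(CC(C)C)NC(=O)OCc1ccccc1)C(=O)C(=O)NCCCN1CCCc2ccccc21` carries the change (2-(1,2,3,4-tetrahydroquinolin-1-yl)ethyl in place of isoquinolin-1-yl on a saturated chain carbon bound to an amide-type nitrogen). Among the measured compounds shown here, of the measured steps, only the one from compound 1 to compound 2 bears on it, and it concerns the same position: exchanging a chain-linked phenyl group for the ring-fused isoquinolin-1-yl gave the modest gain recorded above. Compound 3 moves back toward a chain-linked aromatic, so a step in the opposite direction, of similar or smaller size, is expected. Compound 3 is therefore estimated at 500 nM in this assay, within 150 nM to 1600 nM, a step of a 2.0-fold higher number from compound 2 to compound 3 (0.30 log units; within the scatter) that is expected to be modest.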

Compound 3, inhibition constant: 370 nM
Beside the measured number, compound 3's estimate is 1.4-fold (0.13 log units) above it, within the range that was stated.
By their numbers in this assay, from the lowest: compounds 2 and 3 (each within the scatter of the next); then compound 1.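

In this assay, 2-(1,2,3,4-tetrahydroquinolin-1-yl)ethyl in place of isoquinolin-1-yl gives a 1.5-fold higher number from compound 2 to compound 3 (0.17 log units; within the scatter), so the two groups cannot be told apart on this read-out, even though the entering group brings a non-aromatic ring with its nitrogen and a longer link to the amide-type nitrogen. With 1,2,3,4-tetrahydroquinolin-1-yl in place of phenyl, the listed step is a 2.2-fold lower number from compound 1 to compound 3 (0.33 log units; beyond the scatter), a modest one, which shows that the lower number relative to compound 1 is not confined to the isoquinolin-1-yl group of compound 2. No supporting data are available to explain either step.

The compounds shown leave open whether the ring nitrogen matters at all, which a naphthyl group in place of isoquinolin-1-yl, or a 1,2,3,4-tetrahydronaphthalenyl group in place of 1,2,3,4-tetrahydroquinolin-1-yl, would test. They also leave open how the number responds to chain length, which a shorter or longer carbon chain carrying 1,2,3,4-tetrahydroquinolin-1-yl at this position would address.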